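Changing the Carboxyphenyl End of Compound 1

A few compounds are considered here, and "the series" means these few. Any claim that something is new, unique, unknown or untested is made for them only; others in the source may bear on it.

Compound 1 `Cc1c(OCCCCOc2ccc(C(=O)O)c(Cl)c2)ccc(C(=O)CC(C)C)c1O` was tested in an assay on HEK293 cells for positive allosteric modulation of metabotropic glutamate receptor 2 (Rattus norvegicus), read by thallium flux, with a stated time of 2.5 min (on this read-out lower numbers stand for smaller maximal responses and higher numbers for larger maximal responses), and gave 80.5%. Among the three measured compounds it stands second highest: compound 3 `Cc1c(OCCCCOc2ccc(C(=O)O)c(Cl)c2)ccc(C(=O)CC2CCCC2)c1O` gives 80.8%, and compound 2 `CCC(=O)c1ccc(OCCCCOc2ccc(F)c(C(=O)O)c2)c(C)c1O` gives 66.6%. Going by the values given here, the only single-place step measured, a number 0.3 percentage points higher from compound 1 to compound 3 (within the scatter), concerns the saturated chain carbon bound to a carbonyl carbon and left the maximal response unchanged within the scatter. Compound 4 `Cc1cc(C(=O)O)ccc1OCCCCOc1ccc(C(=O)CC(C)C)c(O)c1C` differs from compound 1 in one place: 4-carboxy-2-methylphenyl in place of 4-carboxy-3-chlorophenyl on an oxygen on a saturated carbon. Among the compounds with values here, no measured step touches this group on the oxygen on a saturated carbon, and compound 2 differs from compound 1 in more than one place, so its lower value cannot be tied to any one change. Within the data shown here, with no direct precedent, the step of a number 5.5 percentage points lower from compound 1 to compound 4 (within the scatter) is expected to be small, near or somewhat below compound 1, with no clear direction beyond the scatter. Compound 4 is therefore estimated to reach 75%, with a range from 58% to 88%.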

Compound 4, largest response reached (reported as percent of maximum), in percent of the reference or control that the assay uses: 83.9%
Compound 4: middle estimate off by 8.9 percentage points, on the low side, and the stated range covers the measured number.
By their numbers in this assay, from the lowest: compound 2; then compounds 1, 3 and 4 (each within the scatter of the next).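

In this assay, putting 4-carboxy-2-methylphenyl in place of 4-carboxy-3-chlorophenyl on an oxygen on a saturated carbon gives a number 3.4 percentage points higher from compound 1 to compound 4 (within the scatter). Going by these compounds alone, this is the first single-place step at the carboxyphenyl end, and it shows that, in this pair, the chlorine can give way to a methyl group, in the positions those two group names print, with the maximal response staying level. Nothing available explains why the response stays level under this exchange.

Going by these compounds, whether the same exchange holds up with the cyclopentyl group of compound 3 remains open, and the lower value of compound 2 is still not tied to any one change. Also open, on these data alone, is what an amide or a tetrazole would give in place of the carboxylic acid on this ring.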